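The compounds below may be only part of what the source reports. "The series", "measured", "known", "first", "only" and "open" are said of these compounds alone.

Of the compounds shown here, two have been measured in an assay on isolated protein for inhibition of malate dehydrogenase, cytoplasmic (Sus scrofa); a lower number here means a stronger inhibitor, a higher number a weaker inhibitor. Compound 1 `N#Cc1cc(CCOc2cc(O)c3c(=O)cc(C(=O)O)oc3c2)ccc1NC(=O)C(=O)O` gives 13600 nM. Compound 2 `COc1ccc(CNC(=O)c2cc(=O)c3c(O)cc(OCCc4ccc(NC(=O)C(=O)O)cc4)cc3o2)cc1` gives 4880 nM, which is the lower of the two numbers; the gap between compound 2 and compound 1 lies beyond the usual scatter of this assay. Among the measured compounds shown here, compound 1 and compound 2 differ in more than one place, so their two values show only that compound 1 is the weaker inhibitor of the pair, and no single change can be read from them.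

The step now followed leads from compound 2 to compound 3 `COc1ccc(CNC(=O)c2cc(=O)c3c(O)cc(OCCc4ccc(NC(=O)C(=O)O)c(C#N)c4)cc3o2)cc1`, with cyano in place of hydrogen on an aromatic carbon. For the measured compounds named here, no pair of measured compounds isolates this change, so the size of the step must be guessed. Compound 1 also carries a cyano group in this position yet differs elsewhere as well, so its value of 13600 nM in this assay cannot be counted as evidence on its own. The cyano group is small, and compound 3 is expected to stay close to compound 2, with a step of a 1.3-fold higher number from compound 2 to compound 3 (0.12 log units; within the scatter) no larger than the scatter or slightly towards a higher number. Compound 3 is therefore estimated at 6500 nM, within a range from 2500 nM to 17000 nM.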

Compound 3, half-maximal inhibitory concentration: 10900 nM
Compound 3: the middle estimate sits 1.7-fold (0.22 log units) below what was measured; the measured number falls inside the stated range.
By their numbers in this assay, from the lowest: compound 2; then compounds 3 and 1 (each within the scatter of the next).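

Read in this assay with everything else held fixed, cyano in place of hydrogen on the aromatic carbon ortho to a (carboxycarbonyl)amino group gives a 2.2-fold higher number from compound 2 to compound 3 (0.35 log units; beyond the scatter) and so yields a weaker inhibitor, a modest loss that the first two compounds could not isolate. The new compound also gives a second single change, since (4-methoxybenzyl)amino in place of hydroxy on a carbonyl carbon gives a 1.2-fold lower number from compound 1 to compound 3 (0.10 log units; within the scatter) and so, with the cyano group present, this exchange does not separate the two compounds. No measurement shown here accounts for either step.

Going by these compounds, what the cyano group does on a compound that keeps the carboxylic acid on that carbonyl carbon stays open, so it cannot be said whether the two changes act independently of each other. Also open, on these data alone, is how fluorine, chlorine, a methyl group or a methoxy group on the same aromatic carbon would compare with cyano and with hydrogen, and so whether the loss belongs to cyano alone or to any group at this position.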